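Dropping the Aryl Methyl of an EP4 Acylsulfonamide

A few compounds are considered here, and "the series" means these few. Any claim that something is new, unique, unknown or untested is made for them only; others in the source may bear on it.

Two compounds carry numbers in an assay on cells for displacement of a labelled ligand from prostaglandin E2 receptor EP4 subtype (Homo sapiens), read by scintillation counting; on this read-out higher numbers stand for weaker inhibition and lower numbers for stronger inhibition. Compound 1 `COc1ccc(-c2ccc(OCc3cc(C(=O)O)oc3C)cc2)cc1OC` gives 2800 nM in this assay. Compound 2 `COc1ccc(-c2ccc(OCc3cc(C(=O)NS(=O)(=O)c4ccccc4)oc3C)cc2)c(C)c1` gives 21 nM in this assay, the lower of the two numbers, and the gap between compound 1 and compound 2 lies beyond the scatter. Since these two differ in more than one place, nothing beyond their two values can be drawn from them.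

Compound 3 `COc1ccc(-c2ccc(OCc3cc(C(=O)NS(=O)(=O)c4ccccc4)oc3C)cc2)cc1` has not yet been measured. It differs from compound 2 in a single place: hydrogen in place of methyl on an aromatic carbon. Going by the values given here, no measured pair shows this single change, so the size of the step can only be expected. The author expects a modest weakening, a step of a 2.9-fold higher number from compound 2 to compound 3 (0.46 log units; beyond the scatter) in this assay, which may reach beyond the scatter. Compound 3 is therefore estimated at 60 nM, within a range from 15 nM to 250 nM.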

Compound 3, inhibition constant: 5 nM
Estimate against measurement, compound 3: 12-fold (1.08 log units) above; the measured number lies below the stated range.
By their numbers in this assay, from the lowest: compound 3; then compound 2; then compound 1.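

In this assay, going from 4-methoxy-2-methylphenyl to 4-methoxyphenyl gives a 4.2-fold lower number from compound 2 to compound 3 (0.62 log units; beyond the scatter), so in this pair the methyl, ortho to a large group, is not required for the low number, and inhibition is stronger with hydrogen on this aromatic carbon. Going by these compounds alone, this is the first comparison here that isolates a single place, as compound 1 differs from the other two in more than one place and says nothing about this position. Nothing available explains why the number falls when the methyl leaves.

What the compounds shown leave open is how other groups on this carbon, such as fluorine, chlorine or ethyl, would compare with hydrogen and methyl. They also leave open whether the same change would give a similar step on a different core.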